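Imide nitrogen substitution in a weak alpha-glucosidase inhibitor series

The compounds below may be only part of what the source reports. "The series", "measured", "known", "first", "only" and "open" are said of these compounds alone.

Measured compounds:
compound 1, `Cc1ccc(S(=O)(=O)Nc2ccc3c(c2)C(=O)N(C)C3=O)cc1`: > 200000 nM
compound 2, `Nc1ccc2c(c1)C(=O)N(CCNc1ccccc1)C2=O`: 144000 nM

In an assay on isolated protein for inhibition of lysosomal alpha-glucosidase (Rattus norvegicus), read by colorimetric assay (a lower number here means a stronger inhibitor, a higher number a weaker inhibitor), compound 1 gives > 200000 nM, which is a limit of the assay and not a number (the limit of > 200000 nM in this assay, at which 1 of the 2 values shown sits). Compound 2, which carries a chain bearing an aniline-type group on the imide nitrogen of the shared core, gives 144000 nM in this assay. Within the data shown here, the two values show only that both compounds are weak in this assay.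

Compound 3, `Cc1ccc(S(=O)(=O)Nc2ccc3c(c2)C(=O)N(CCOc2ccc(O)cc2)C3=O)cc1`, has not yet been measured. It differs from compound 1 by (4-hydroxyphenoxy)methyl in place of hydrogen on a saturated chain carbon bound to an amide-type nitrogen in a ring. Among the measured compounds shown here, no measured pair tracks this kind of change, so its size cannot be read from the data; the aryl-bearing chain of compound 2 and its value 144000 nM give the only hint that such a substituent on the imide nitrogen is compatible with a measurable, though weak, result.

Compound 3 is therefore expected to give 150000 nM, within a range from 50000 nM to 300000 nM. The step of an at least 1.3-fold lower number from compound 1 to compound 3 (0.12 log units; that floor lies within the scatter) that this estimate implies is expected to be small and directed toward modestly stronger inhibition, with a fair chance that this assay again reports only a limit.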

Compound 3, half-maximal inhibitory concentration: 47700 nM
For compound 3 the middle estimate is 3.1-fold (0.50 log units) above the measured one; the whole stated range lies above it.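

In this assay, (4-hydroxyphenoxy)methyl in place of hydrogen on a saturated chain carbon bound to an amide-type nitrogen in a ring gives an at least 4.1-fold lower number from compound 1 to compound 3 (0.62 log units; beyond the scatter). Among these compounds, this is the only measured step at this position, and it shows that the position accepts a group bearing an aromatic ring with a gain in inhibition that lies beyond the scatter, although compound 3 remains a weak inhibitor. The value of compound 1 is a limit of the assay and not a number, so the step gives only a floor and its full size cannot be read: the limit of > 200000 nM in this assay, at which 1 of the 3 values shown sits.

The compounds shown leave open which part of the (4-hydroxyphenoxy)methyl group carries the step, since a plain phenoxymethyl, a methoxy in place of the hydroxyl, or a longer chain to the same ring could each read differently. From the compounds shown here alone, compound 2 differs from compound 3 in more than one place and so cannot settle this, and whether an amine or a carboxylic acid at the end of the chain would shift the reading in this assay also stays open.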